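Carboxamide substituent at the ester position of a triazole

A few compounds are considered here, and "the series" means these few. Any claim that something is new, unique, unknown or untested is made for them only; others in the source may bear on it.

Measured compounds:
compound 1, `NC(=O)c1nc(-c2ccccc2)n(-c2ccc(S(N)(=O)=O)cc2)n1` — 43%
compound 2, `NNC(=O)c1nc(-c2ccccc2)n(-c2ccc(S(N)(=O)=O)cc2)n1` — 32%
compound 3, `COC(=O)c1nc(-c2ccccc2)n(-c2ccc(S(N)(=O)=O)cc2)n1` — 38%

All three share one core and differ only in the group on the carbonyl carbon. In a functional assay on the whole organism for inhibition, with Rattus norvegicus as the target, read by paw edema, with stated times of 30 min and 1 h, at a dose of 0.28 mmol/kg by the oral route (on this read-out higher numbers stand for more inhibition at the one dose given (going by the name of the read-out) and lower numbers for less inhibition), compound 3 gives 38%, and the steps of a number 5 percentage points lower from compound 1 to compound 3 (within the scatter) and a number 6 percentage points higher from compound 2 to compound 3 (within the scatter) place it within the scatter of both other compounds, so no order among the three can be claimed. Among the measured compounds shown here, the only step beyond the scatter is a number 11 percentage points lower from compound 1 to compound 2 (beyond the scatter).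

Compound 4, `CC(C)NC(=O)c1nc(-c2ccccc2)n(-c2ccc(S(N)(=O)=O)cc2)n1`, is the next compound to be tested. The change from compound 3 is isopropylamino in place of methoxy on a carbonyl carbon. This brings back an amide, as in compound 1, but now with an isopropyl group on its nitrogen, which resembles the change in compound 1 to compound 2, where adding a group on the amide nitrogen cost a modest amount. On that basis the step of a number 3 percentage points lower from compound 3 to compound 4 (within the scatter) is expected to be small, at most a modest drop. Compound 4 is therefore estimated at 35%, within 22% to 48%.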

Compound 4, a percentage reported as inhibition, in the whole organism at one dose (the size of the read-out at that dose, not a potency): 21%
Compound 4: middle estimate off by 14 percentage points, on the high side; measured number outside the range, below it.
By their numbers in this assay, from the lowest: compound 4; then compounds 2, 3 and 1 (each within the scatter of the next, the first and the last beyond it).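

At this carbonyl carbon, an amide bearing isopropyl on its nitrogen gives a clear loss in this assay relative to the methoxy compound (a number 17 percentage points lower from compound 3 to compound 4 (beyond the scatter)), whereas the plain amide of compound 1 stayed within the scatter of that compound. Replacing the amide hydrogen with isopropyl costs more (a number 22 percentage points lower from compound 1 to compound 4 (beyond the scatter)), and isopropyl also falls short of amino on the same nitrogen (a number 11 percentage points lower from compound 2 to compound 4 (beyond the scatter)), so the numbers drop from hydrogen through amino to isopropyl, with each step beyond the scatter. No measurement available here explains this drop.

As far as these compounds go, it remains open whether methylamino, a longer chain such as butylamino, or a ring amine such as morpholine on the carbonyl carbon would fit this order. A carboxylic acid at the same place also remains to be placed against these compounds.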